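The source may report more compounds than this note shows. Statements on the series, on what has been measured and on what is new or still open speak of the compounds shown alone.

Compound 1 `CCCCC[C@@H](C[C@@H](O)C[C@H]1CC=CC(=O)O1)OC`, compound 2 `CCCCC[C@H](C[C@@H](O)C[C@@H]1CC=CC(=O)O1)OC` and compound 3 `CCCCC[C@H](C[C@H](O)C[C@@H]1CC=CC(=O)O1)OC` have the same atoms and bonds and differ only in the configuration drawn at their stereocentres, the carbons whose three-dimensional arrangement can vary. In a functional assay on A2780 cells (Homo sapiens) for cytotoxicity, read by MTT assay, with a stated time of 24 h (a lower number here means a stronger inhibitor, a higher number a weaker inhibitor), compound 1 gives 33700 nM, compound 2 gives 54500 nM and compound 3 gives 22900 nM. Compound 3 therefore stands level with compound 1, as a 1.5-fold lower number from compound 1 to compound 3 (0.17 log units; within the scatter) shows, and clearly apart only from compound 2, with a 2.4-fold lower number from compound 2 to compound 3 (0.38 log units; beyond the scatter).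

The next compound, compound 4 `CCCCC[C@@H](C[C@H](O)C[C@H]1CC=CC(=O)O1)OC`, changes only the drawn configuration again: the two compounds have the same atoms and bonds and differ only in configuration as drawn: 2 of 3 stereo elements differ; a stereocentre at a saturated chain carbon is drawn R in compound 3 and S in compound 4; a stereocentre at a saturated ring carbon is drawn S in compound 3 and R in compound 4. The closest guide is a 1.6-fold higher number from compound 1 to compound 2 (0.21 log units; within the scatter), since that step also changes one saturated chain carbon and one saturated ring carbon, and it stays within the scatter. Even inverting all the stereocentres, in the step from compound 1 to compound 3 described above, stays within the scatter. Going by the values given here, the one step beyond it is small. No sizeable change is therefore expected in this assay, and the data favour no clear direction. The expected change is a 1.3-fold higher number from compound 3 to compound 4 (0.12 log units; within the scatter), which would remain within the scatter. The estimate for compound 4 is 30000 nM, with an expected range from 15000 nM to 60000 nM.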

Compound 4, half-maximal inhibitory concentration: 53700 nM
Compound 4: the middle estimate sits 1.8-fold (0.25 log units) below what was measured, and the stated range covers the measured number.
By their numbers in this assay, from the lowest: compounds 3, 1, 4 and 2 (each within the scatter of the next, the first and the last beyond it).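

The new step shows that changing a saturated chain carbon and a saturated ring carbon together can separate two compounds, with a 2.3-fold higher number from compound 3 to compound 4 (0.37 log units; beyond the scatter), although the same kind of change stayed within the scatter in a 1.6-fold higher number from compound 1 to compound 2 (0.21 log units; within the scatter); that separation can only come from the drawn configuration: the fact that compounds 3 and 4 differ only in the configuration as drawn

A second pair of mirror images now also stays within the scatter, with a 1.0-fold lower number from compound 2 to compound 4 (0.01 log units; within the scatter), matching a 1.5-fold lower number from compound 1 to compound 3 (0.17 log units; within the scatter), so in this assay neither mirror-image pair can be told apart. Inverting one saturated chain carbon gives a 1.6-fold higher number from compound 1 to compound 4 (0.20 log units; within the scatter), which is within the scatter, while a single inversion at a saturated chain carbon elsewhere in the set gives a 2.4-fold lower number from compound 2 to compound 3 (0.38 log units; beyond the scatter), which is beyond it, so the outcome of such a change depends on the configuration at the other stereocentres.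

All four compounds share the same atoms and bonds, so these results leave open whether configuration would matter more or less in a compound carrying an amine or a longer chain. They also leave open whether any change to the shared core itself would move the number further than these changes of configuration do.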